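Methyl for Fluoro on the Triazole Aryl Group

The source may report more compounds than this note shows. Statements on the series, on what has been measured and on what is new or still open speak of the compounds shown alone.

Compound 1 `C=C1C[C@]23C[C@@]1(O)CC[C@H]2c1ccc(OS(=O)(=O)c2ccc(C)cc2)c(C)c1[C@@H]3Cn1cc(-c2ccc(C)cc2)nn1`: > 20000 nM in a functional assay on SMMC-7721 cells (Homo sapiens) for cytotoxicity, read by MTT assay, with a stated time of 4 days (on this read-out higher numbers stand for weaker inhibition and lower numbers for stronger inhibition), a limit only.
Compound 2 `C=C1C[C@]23C[C@@]1(O)CC[C@H]2c1ccc(OS(=O)(=O)c2ccc(C)cc2)c(C)c1[C@@H]3Cn1cc(-c2ccc(F)cc2)nn1`: > 20000 nM in this assay, a limit only.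
Compound 3 `C=C1C(=O)[C@]23C[C@@]1(O)CC[C@H]2c1ccc(OS(=O)(=O)c2ccc(C)cc2)c(C)c1[C@@H]3Cn1cc(-c2ccc(F)cc2)nn1`: 4280 nM in this assay.

Compound 1 and compound 2 share one core and differ by methyl in place of fluoro on an aromatic carbon. With both values standing at the limit of > 20000 nM in this assay, at which 2 of the 3 values shown sit, the step between them is not readable: a step that the two limits leave unreadable from compound 2 to compound 1. Compound 3 carries a different core; how the cores of compound 2 and compound 3 differ is not broken down here. In this assay, among the compounds with values here, compound 3 gives 4280 nM, the only number among the three.

Compound 4 `C=C1C(=O)[C@]23C[C@@]1(O)CC[C@H]2c1ccc(OS(=O)(=O)c2ccc(C)cc2)c(C)c1[C@@H]3Cn1cc(-c2ccc(C)cc2)nn1` is not yet measured. It differs from compound 3 by methyl in place of fluoro on an aromatic carbon, the same change as from compound 2 to compound 1, at a place described in identical words. That earlier step is unreadable, so the expectation rests on compound 3 and its 4280 nM. Compound 4 is expected close to compound 3, a step of a 1.2-fold higher number from compound 3 to compound 4 (0.07 log units; within the scatter). The value of compound 4 is estimated at 5000 nM, within a range from 1500 nM to 20000 nM.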

Compound 4, half-maximal inhibitory concentration: 4410 nM
Compound 4: middle estimate off by 1.1-fold (0.05 log units), on the high side; low and high end bracket the measured number.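

In this assay, methyl in place of fluoro on an aromatic carbon gives a 1.0-fold higher number from compound 3 to compound 4 (0.01 log units; within the scatter), so on this core the 4-fluorophenyl and 4-methylphenyl groups cannot be told apart. The same change on the core of compound 1 and compound 2 cannot be read, because both of those values are limits of the assay and not numbers: the limit of > 20000 nM in this assay, at which 2 of the 4 values shown sit. The series therefore offers a single readable instance of this change, which shows that it is tolerated on one core but neither confirms nor refutes that it would behave alike on the other.

The compounds shown leave open whether any group at this place, para to a large group, would separate from the pair seen here, with compound 3 at 4280 nM as the reference; an amine, a carboxylic acid or a longer chain such as butyl would test this. They also leave open whether the flat result on this core would hold for such groups on the core of compound 1.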